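Adding a Third Methoxy to a Bis-Benzylidene Cyclohexanone

The compounds below may be only part of what the source reports. "The series", "measured", "known", "first", "only" and "open" are said of these compounds alone.

Measured so far in a functional assay on A549 cells (Homo sapiens) for cytotoxicity, read by MTT assay, with a stated time of 72 h; on this read-out higher numbers stand for weaker inhibition and lower numbers for stronger inhibition:
compound 1 `COc1cccc(/C=C2\CCC/C(=C\c3cccc(OC)c3OC)C2=O)c1`: 16400 nM
compound 2 `COc1ccc(/C=C2\CCC/C(=C\c3cccc(OC)c3OC)C2=O)cc1OC`: 14400 nM
compound 3 `COc1cc(/C=C2\CCC/C(=C\c3ccc(OC)c(OC)c3)C2=O)cc(OC)c1`: 5100 nM

All three share a core with two aromatic rings carrying methoxy groups. Compound 1 and compound 2 differ in one place: methoxy in place of hydrogen on an aromatic carbon. That change produced a 1.1-fold lower number from compound 1 to compound 2 (0.06 log units; within the scatter), so the two values show no separation that can be trusted. Compound 3 gives the lowest number of the three; its distance from compound 2 and from compound 1 lies beyond the scatter. The difference between the core of compound 1 and the core of compound 3 is not broken down here.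

Compound 4 `COc1ccc(/C=C2\CCC/C(=C\c3cc(OC)c(OC)c(OC)c3)C2=O)cc1OC` differs from compound 3 in one place: methoxy in place of hydrogen on an aromatic carbon. Among the measured compounds shown here, this is the same kind of change as the one from compound 1 to compound 2, but not the same: in compound 4 the new group sits ortho to two methoxy groups, while in compound 2 it sat ortho to a methoxy group. For the measured compounds named here, because the earlier step of a 1.1-fold lower number from compound 1 to compound 2 (0.06 log units; within the scatter) stayed within the scatter, a small step is expected here as well, with wide uncertainty since only one example exists. For compound 4 the expected value in this assay is 4300 nM, with a range from 1600 nM to 12000 nM. This corresponds to an expected step of a 1.2-fold lower number from compound 3 to compound 4 (0.07 log units; within the scatter).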

Compound 4, half-maximal inhibitory concentration: 2900 nM
Beside the measured number, compound 4's estimate is 1.5-fold (0.17 log units) above it, within the range that was stated.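

In this assay, among the compounds shown here, putting a methoxy group in place of a hydrogen on an aromatic carbon gave a 1.8-fold lower number from compound 3 to compound 4 (0.25 log units; within the scatter), so this second example of the change, like the first, gives no step that can be told apart from the ordinary spread of repeated measurements. On these two cores the change carried over with the same outcome, a step too small to read, and the two steps cannot be told apart from each other: the same change on two cores in this assay, a 1.1-fold lower number (0.06 log units; within the scatter) from compound 1 to compound 2 and a 1.8-fold lower number (0.25 log units; within the scatter) from compound 3 to compound 4, 1.5-fold (0.19 log units) apart, within the scatter of two such steps. This does not show that the methoxy group has no influence, nor that a step of this size would follow on any other core, as two small steps from two pairs of compounds cannot support a rule for the whole series, and the added group sits in a different place in each pair.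

Still open, from the compounds shown here alone, is whether a different group at the position filled in compound 4, such as a hydroxyl, an amine or a carboxylic acid, would give a step beyond the scatter. Going by these compounds, it is also open whether a longer chain, such as ethoxy or propoxy, would do so where the methoxy group now stands.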